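A few compounds are considered here, and "the series" means these few. Any claim that something is new, unique, unknown or untested is made for them only; others in the source may bear on it.

Of the compounds shown here, two built on the same core have been measured in an assay on mitochondria from L6 cells (Rattus norvegicus) for activation, with a stated time of 90 min; a lower number here means that less compound is needed, a higher number that more compound is needed for the effect. Compound 1, `FC(F)(F)Oc1cccc(Nc2nc3nonc3nc2Nc2cccc(OC(F)(F)F)c2)c1`, carries two trifluoromethoxy groups; in this assay compound 1 gives 1100 nM. Compound 2, `Cc1cccc(Nc2nc3nonc3nc2Nc2ccccc2F)c1`, carries a methyl group and a fluorine; in this assay compound 2 gives 1500 nM. The gap between these two values lies within the usual scatter of repeated measurements, so the two compounds cannot be told apart on these numbers alone.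

Compound 3, `Fc1ccccc1Nc1nc2nonc2nc1Nc1cccc(OC(F)(F)F)c1`, has not yet been measured. It differs from compound 2 in one place: trifluoromethoxy in place of methyl on an aromatic carbon. This change moves compound 3 closer in build to compound 1, which already carries the trifluoromethoxy group. Among the compounds with values here, no step between measured compounds shows what this change does on its own. Because compound 1 gives 1100 nM and compound 2 gives 1500 nM, two numbers within the scatter of each other, no shift beyond the scatter is expected in this assay, and the step is estimated as a 1.3-fold lower number from compound 2 to compound 3 (0.10 log units; within the scatter). Compound 3 is therefore expected to give about 1200 nM in this assay, within a range from 500 nM to 2800 nM.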

Compound 3, half-maximal effective concentration: 600 nM
Compound 3: the middle estimate sits 2.0-fold (0.30 log units) above what was measured; the measured number falls inside the stated range.
By their numbers in this assay, from the lowest: compounds 3, 1 and 2 (each within the scatter of the next, the first and the last beyond it).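

In this assay, within the data shown here, trifluoromethoxy in place of methyl on an aromatic carbon, meta to a large group, gives a 2.5-fold lower number from compound 2 to compound 3 (0.40 log units; beyond the scatter) and so is the one change here with an effect that stands clear of the scatter, although that effect is modest. By contrast, 2-fluorophenyl in place of 3-(trifluoromethoxy)phenyl on a nitrogen on an aromatic ring gives a 1.8-fold lower number from compound 1 to compound 3 (0.26 log units; within the scatter) and therefore cannot be told apart from no change, so in this small set the difference that can be read comes from replacing methyl with trifluoromethoxy. Nothing measured here bears on what lies behind either step.

The compounds shown leave open how a methoxy group, a chlorine atom, an amine or a carboxylic acid at this position would compare with methyl and trifluoromethoxy. Among these compounds, they also leave open whether the step from methyl to trifluoromethoxy would hold with a group other than 2-fluorophenyl on the other nitrogen, since this single pair is the only place where that change can be read.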